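Moving the chlorine on the benzamide ring

A few compounds are considered here, and "the series" means these few. Any claim that something is new, unique, unknown or untested is made for them only; others in the source may bear on it.

Measured so far:
compound 1, `Cc1cc(=O)[nH]c2cc(NC(=O)c3ccccc3Cl)ccc12`: 1.55
compound 2, `Cc1cc(=O)[nH]c2cc(NC(=O)c3c(Br)cccc3Br)ccc12`: 1.75

Of the compounds shown here, two sharing the same core have been measured in a physicochemical assay for lipophilicity; a higher number here means a more lipophilic compound, a lower number a more polar compound. In this assay compound 1 gives 1.55, and compound 2 gives 1.75. The two numbers sit within the usual scatter of one another, so neither is set apart from the other.

Compound 3, `Cc1cc(=O)[nH]c2cc(NC(=O)c3ccc(Cl)cc3)ccc12`, has not yet been measured. It differs from compound 1 in one place: 4-chlorophenyl in place of 2-chlorophenyl on a carbonyl carbon. Within the data shown here, no step between measured compounds covers a change of this kind, so the expectation rests on the two measured values alone. A small step is expected, if any, and not one clearly beyond the scatter. Compound 3 is estimated at 1.8, with a range from 1.4 to 2.2, which would mean an expected step of a number 0.25 log units higher from compound 1 to compound 3 (within the scatter).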

Compound 3, partition coefficient: 1.69
Compound 3: the middle estimate sits 0.11 log units above what was measured; the measured number falls inside the stated range.
By their numbers in this assay, from the lowest: compounds 1, 3 and 2 (each within the scatter of the next).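

In this assay, among these compounds, swapping 2-chlorophenyl for 4-chlorophenyl on a carbonyl carbon gives a number 0.14 log units higher from compound 1 to compound 3 (within the scatter) and is the first change that can be read on its own, since compound 1 and compound 3 differ in one place only. The two groups have the same atoms and differ only in how they are joined, and on these numbers this change does not set compound 3 apart from compound 1. No measurement shown here offers an explanation for this result.

As far as these compounds go, what remains open is whether a different group on this benzamide ring, such as an amine or a carboxylic acid in place of the chlorine, would give a step beyond the scatter. From the compounds shown here alone, it is also open whether the same swap would behave alike on another core.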